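Replacing a hydroxy-methoxyphenyl with dimethoxyphenyl: clearance outlook

This account rests on a few compounds, and the source may have more. Where it says the series, first, only, none or still open, it means among the compounds named here.

Compound 1 `COc1cccc(O)c1C(=O)N1CCC(=CC(=O)N[C@@H]2CCN(Cc3ccc4cc(F)ccc4c3)C2)CC1` — 192 mL/min/kg
Compound 2 `COc1ccc(O)c(C(=O)N2CCC(=CC(=O)N[C@@H]3CCN(Cc4ccc5cc(F)ccc5c4)C3)CC2)c1` — 119 mL/min/kg

Of the compounds shown here, two have been measured in an in vitro ADME assay on microsomes from liver (Homo sapiens) for metabolic stability; on this read-out lower numbers stand for slow clearance and higher numbers for fast clearance. Compound 1 gives 192 mL/min/kg and compound 2 gives 119 mL/min/kg. Among the compounds with values here, the only measured step, a 1.6-fold lower number from compound 1 to compound 2 (0.21 log units; within the scatter), falls within the scatter, so compound 2 cannot be told apart from compound 1 on this read-out; both numbers sit at the fast-clearance end.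

Compound 3 `COc1ccc(C(=O)N2CCC(=CC(=O)N[C@@H]3CCN(Cc4ccc5cc(F)ccc5c4)C3)CC2)cc1OC` is the next candidate. It differs from compound 2 as follows: 3,4-dimethoxyphenyl in place of 2-hydroxy-5-methoxyphenyl on a carbonyl carbon. Within the data shown here, no measured step bears on this change. Among the measured compounds shown here, the one step in hand exchanged 2-hydroxy-6-methoxyphenyl for 2-hydroxy-5-methoxyphenyl and stayed within the scatter; it says nothing about losing the hydrogen-bond donor or about 3,4-dimethoxyphenyl. With nothing to point elsewhere, compound 3 is expected to land near compound 2, at about 130 mL/min/kg, between 60 mL/min/kg and 290 mL/min/kg. The expected step is a 1.1-fold higher number from compound 2 to compound 3 (0.04 log units; within the scatter), nothing beyond the scatter.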

Compound 3, clearance: 246 mL/min/kg
Compound 3: middle estimate off by 1.9-fold (0.28 log units), on the low side; the measured number falls inside the stated range.
By their numbers in this assay, from the lowest: compounds 2, 1 and 3 (each within the scatter of the next, the first and the last beyond it).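

Within the data shown here, on this assay this change on the carbonyl carbon is the first to reach beyond the usual scatter: putting 3,4-dimethoxyphenyl in place of 2-hydroxy-5-methoxyphenyl gives a 2.1-fold higher number from compound 2 to compound 3 (0.32 log units; beyond the scatter) as its step. Put in place of 2-hydroxy-6-methoxyphenyl instead, the same group gives a 1.3-fold higher number from compound 1 to compound 3 (0.11 log units; within the scatter) and stays within the scatter, so the size of the step depends on which hydroxy-methoxyphenyl group leaves. The group at this position can therefore move the number somewhat, yet all three compounds remain at the fast-clearance end.

Still open, going by these compounds, is whether a different group here, such as an aminophenyl or a phenyl carrying a carboxylic acid, would reach slow clearance. No measurement shown explains why the two steps differ.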